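Thiophene in Place of Methoxyphenyl: What to Expect

The source may hold more compounds than are shown below. What is called first, only, known or untested is meant among the compounds shown, and "the series" means these compounds.

Three compounds share one core and differ only in a single aryl group. In a functional assay on HT-29 cells (Homo sapiens) for inhibition, read by sulforhodamine B assay, with a stated time of 48 h, tested at 10 uM (on this read-out higher numbers stand for more inhibition at the one concentration tested (going by the name of the read-out) and lower numbers for less inhibition), compound 3 `COc1ccccc1-c1cn2ccnc2c(-c2ccc3ncn(C4CCCCC4)c3c2)n1` gives 11.1%; compound 2 `CC(=O)c1ccc(-c2cn3ccnc3c(-c3ccc4ncn(C5CCCCC5)c4c3)n2)cc1` gives 9.2% and compound 1 `c1cn2cc(-c3ccsc3)nc(-c3ccc4ncn(C5CCCCC5)c4c3)c2n1` gives 5.68%. Compound 3 thus holds the highest of the three numbers, though both others lie within the scatter of it. Compound 4 `c1csc(-c2cn3ccnc3c(-c3ccc4ncn(C5CCCCC5)c4c3)n2)c1` differs from compound 3 by thiophen-2-yl in place of 2-methoxyphenyl on an aromatic carbon. The closest guide is a number 5.4 percentage points higher from compound 1 to compound 3 (within the scatter), and a number 3.5 percentage points higher from compound 1 to compound 2 (within the scatter) together with a number 1.9 percentage points higher from compound 2 to compound 3 (within the scatter) tell the same story: each aryl swap so far stayed within the scatter. Compound 1, which also carries a thiophene, sits furthest from compound 3. The analyst therefore expects a number 4.6 percentage points lower from compound 3 to compound 4 (within the scatter), a small downward drift at most. Compound 4 is estimated at 6.5%, within 0% to 14%.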

Compound 4, a percentage reported as inhibition, at one concentration (the size of the read-out at that concentration, not a potency): 0.09%
Compound 4: the middle estimate sits 6.4 percentage points above what was measured; the range from low to high includes it.
By their numbers in this assay, from the lowest: compounds 4, 1, 2 and 3 (each within the scatter of the next, the first and the last beyond it).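

In this assay this aromatic carbon shows its first aryl swap beyond the scatter, with thiophen-2-yl in place of 2-methoxyphenyl giving (a number 11 percentage points lower from compound 3 to compound 4 (beyond the scatter)). The swap from 4-acetylphenyl stays within the scatter (a number 9.1 percentage points lower from compound 2 to compound 4 (within the scatter)), and thiophen-2-yl and thiophen-3-yl cannot be told apart (a number 5.6 percentage points lower from compound 1 to compound 4 (within the scatter)). No evidence is available to explain the loss from compound 3. On these data alone, whether any aryl group at this position takes the number well beyond those of compounds 2 and 3 remains open. So does the effect of an amine or a carboxylic acid on the 2-methoxyphenyl ring.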